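The source may report more compounds than this note shows. Statements on the series, on what has been measured and on what is new or still open speak of the compounds shown alone.

Compound 1, `O=C(CCSc1nc2cc(Cl)ccc2o1)NC1CCCC1`, stands at the top of the three numbers measured in an ADME assay on microsomes from liver (Homo sapiens) for metabolic stability, read by LC-MS, using NADPH, with a stated time of 45 min, tested at 0.5 uM; on this read-out higher numbers stand for fast clearance and lower numbers for slow clearance. In that assay compound 1 gives 11.3 mL/min/g. The nearest of the other two is compound 3, `O=C(CCCc1nc2cc(Cl)ccc2o1)N1CCCC1`, which in this assay gives 1.4 mL/min/g, a gap beyond the usual scatter of repeated measurements. Further away is compound 2, `O=C(CCSc1nc2cc(F)ccc2o1)N1CCS(=O)(=O)CC1`, which in this assay gives 0.4 mL/min/g, the lowest of the three and again well beyond the scatter from compound 1. Compound 1 is therefore the fastest-cleared of the three on this read-out.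

The next compound to be measured is compound 4, `CN1CCN(C(=O)CCSc2nc3cc(Cl)ccc3o2)CC1`. Compared with compound 1 it differs in one place: 4-methylpiperazin-1-yl in place of cyclopentylamino on a carbonyl carbon. For the measured compounds named here, no pair of measured compounds differs in exactly this way, so the step cannot be read off directly. Both of the other measured compounds carry a different amide partner from compound 1 and both give lower numbers, compound 3 with 1.4 mL/min/g and compound 2 with 0.4 mL/min/g. On that basis the author expects the step from compound 1 to compound 4 to be downward and beyond the scatter, as a 3.8-fold lower number from compound 1 to compound 4 (0.58 log units; beyond the scatter). Compound 4 is estimated to give 3 mL/min/g in this assay, with a range from 1 mL/min/g to 9 mL/min/g.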

Compound 4, intrinsic clearance in a liver preparation (reported as CLH), per the amount of preparation that the assay uses: 1.5 mL/min/g
Compound 4: middle estimate off by 2.0-fold (0.30 log units), on the high side; measured number inside the range.
By their numbers in this assay, from the lowest: compound 2; then compounds 3 and 4 (each within the scatter of the next); then compound 1.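

In this assay the exchange of cyclopentylamino for 4-methylpiperazin-1-yl on a carbonyl carbon gives a 7.5-fold lower number from compound 1 to compound 4 (0.88 log units; beyond the scatter) with the rest of compound 1 unchanged. For the compounds shown here, this is the first reading of the amide partner alone, as compound 2 and compound 3 each differ from compound 1 in more than one place, and it shows that a change at this position by itself can move the number beyond the scatter. The exchange replaces a five-membered ring of carbon only with a six-membered ring holding 2 hetero atoms, and it also removes the amide hydrogen, but nothing measured here accounts for the step.

Going by these compounds alone, the single pair does not separate the ring size, the second ring nitrogen, the methyl group and the amide hydrogen from one another, and an unsubstituted piperazine, a morpholine or a cyclohexylamino group on the same carbonyl would begin to do so. It also leaves open whether the same exchange gives a step of similar size when the sulfur of the chain is replaced by a methylene group or the chlorine on the core by fluorine.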